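The source may hold more compounds than are shown below. What is called first, only, known or untested is meant among the compounds shown, and "the series" means these compounds.

Measured so far in a functional assay on DU-145 cells (Homo sapiens) for antiproliferative activity, read by sulforhodamine B assay, with a stated time of 3 days; a lower number here means a stronger inhibitor of growth, a higher number a weaker inhibitor of growth:

- Compound 1 `COc1ccc(NC(=O)c2cccc(Nc3ncc(F)c(Nc4ccc(F)cc4)n3)c2)cc1`: > 10000 nM, a limit
- Compound 2 `CN(C)c1ccc(C(=O)Nc2cccc(Nc3ncc(F)c(Nc4ccc(F)cc4)n3)c2)cc1`: > 10000 nM, a limit

Compound 2 gives a limit and no number. Among the measured compounds shown here, it stands at the limit of > 10000 nM in this assay, at which 2 of the 2 values shown sit, so the series so far offers no measured step to work from.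

The next compound to be read is compound 3 `CN(C)CC(=O)Nc1cccc(Nc2ncc(F)c(Nc3ccc(F)cc3)n2)c1`. Relative to compound 2, it carries (dimethylamino)methyl in place of 4-(dimethylamino)phenyl on a carbonyl carbon. The amide-type nitrogen and the rest of the shared core stay as they are, and the one six-membered aromatic ring of carbon only leaves with the group.

No step beyond the scatter is expected in this assay, and compound 3 is expected to sit near the same limit. This expectation rests on compound 1 and compound 2, which share (the limit of > 10000 nM in this assay, at which 2 of the 2 values shown sit). Any real shift would have to lie toward stronger inhibition of growth, but none is assumed here. The expected change is a number no higher from compound 2 to compound 3 (the limit leaves the size open). For compound 3 the estimated value is 10000 nM, with an expected range from 3000 nM to 30000 nM.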

Compound 3, concentration for 50% growth inhibition: 1210 nM
Estimate against measurement, compound 3: 8.3-fold (0.92 log units) above, outside the stated range (below it).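

In this assay, the group on the carbonyl carbon proves able to move the series off its limit: (dimethylamino)methyl in place of 4-(dimethylamino)phenyl gives an at least 8.2-fold lower number from compound 2 to compound 3 (0.91 log units; beyond the scatter). The dimethylamino group is present on both sides of this step, so that group alone does not account for the difference; what leaves is the six-membered aromatic ring that carried it. The wider change, (((dimethylamino)methyl)carbonyl)amino in place of (4-methoxyphenyl)carbamoyl on an aromatic carbon, gives an at least 8.2-fold lower number from compound 1 to compound 3 (0.91 log units; beyond the scatter), and both steps have only a lower bound on their size because each starts from a limit: the limit of > 10000 nM in this assay, at which 2 of the 3 values shown sit.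

The compounds shown leave open whether the step depends on the amine at all, since a plain methyl on the same carbonyl carbon would separate the effect of losing the ring from that of keeping the dimethylamino group on a short chain. They also leave open how much room there is around that amine, which a longer chain such as 2-(dimethylamino)ethyl or a morpholine in place of dimethylamino would test.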